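Acyl swap on the carbonyl carbon: compound 2 to compound 4

The source may hold more compounds than are shown below. What is called first, only, known or untested is meant among the compounds shown, and "the series" means these compounds.

In a functional assay on KYSE-450 cells (Homo sapiens) for inhibition, read by MTT assay, with a stated time of 48 h (a lower number here means a stronger inhibitor, a higher number a weaker inhibitor), the measured compounds read:
- compound 1 `CCCCC(=O)N(Cc1ccc(OC)c(O)c1)c1cc(OC)c(OC)c(OC)c1` gives 300 nM
- compound 2 `COc1ccc(CN(C(=O)C(C)Br)c2cc(OC)c(OC)c(OC)c2)cc1O` gives 160 nM
- compound 3 `COc1ccc(CNc2cc(OC)c(OC)c(OC)c2)cc1Br` gives 39800 nM

Compound 2 lies within the scatter of compound 1, and both sit far lower than compound 3. Within the data shown here, no single-place step links compound 3 to the others.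

Compound 4 `C/C=C/C=C/C(=O)N(Cc1ccc(OC)c(O)c1)c1cc(OC)c(OC)c(OC)c1` carries penta-1,3-dien-1-yl in place of 1-bromoethyl on a carbonyl carbon. Among the measured compounds shown here, only one measured step bears on this place, and it stayed within the scatter (a 1.9-fold lower number from compound 1 to compound 2 (0.27 log units; within the scatter)). On that single step, an expected shift in this assay is a 1.4-fold higher number from compound 2 to compound 4 (0.14 log units; within the scatter), which is no change beyond the scatter. For compound 4 the estimated value is 220 nM, with an expected range of 70 nM to 700 nM.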

Compound 4, half-maximal inhibitory concentration: 180 nM
The estimate for compound 4 lay 1.2-fold (0.09 log units) above the measured number, and the stated range covers the measured number.
By their numbers in this assay, from the lowest: compounds 2, 4 and 1 (each within the scatter of the next); then compound 3.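

In this assay, penta-1,3-dien-1-yl on a carbonyl carbon reads level with 1-bromoethyl, with a 1.1-fold higher number from compound 2 to compound 4 (0.05 log units; within the scatter), and level with butyl, with a 1.7-fold lower number from compound 1 to compound 4 (0.22 log units; within the scatter). Butyl, 1-bromoethyl and penta-1,3-dien-1-yl therefore all lie within the scatter of one another at this place, so the series shows no separation among these three groups. No supporting data bear on this result. From the compounds shown here alone, whether this holds for an acyl group carrying an amine or a carboxylic acid, or for a longer chain, remains open.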